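The compounds below may be only part of what the source reports. "The series", "measured", "known", "first", "only" and "open" are said of these compounds alone.

Working notes on the series. Three compounds share one core and differ only in the aryl group on the carbon with a double bond to nitrogen. Compound 1 `COc1ccc(OC)c(/C=N/NC(=O)Nc2ccc(Oc3ccnc(-c4nncn4CCN(C)C)c3)c(F)c2)c1` gives 1950 nM in a functional assay on A549 cells (Homo sapiens) for cytotoxicity, read by MTT assay, with a stated time of 72 h; on this read-out higher numbers stand for weaker inhibition and lower numbers for stronger inhibition; compound 2 `COc1ccc(/C=N/NC(=O)Nc2ccc(Oc3ccnc(-c4nncn4CCN(C)C)c3)c(F)c2)c(OC)c1` gives 2820 nM; compound 3 `CN(C)CCn1cnnc1-c1cc(Oc2ccc(NC(=O)N/N=C/c3cccc(Br)c3)cc2F)ccn1` gives 970 nM. Compound 3 shows the lowest number of the three, although its gap to compound 1 is within the scatter: a 2.0-fold lower number from compound 1 to compound 3 (0.30 log units; within the scatter), while a 2.9-fold lower number from compound 2 to compound 3 (0.46 log units; beyond the scatter). Between the two dimethoxy analogues, a 1.4-fold higher number from compound 1 to compound 2 (0.16 log units; within the scatter).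

Compound 4 `CN(C)CCn1cnnc1-c1cc(Oc2ccc(NC(=O)N/N=C/c3ccc(O)cc3O)cc2F)ccn1` has not been measured. The change from compound 3 is 2,4-dihydroxyphenyl in place of 3-bromophenyl on a carbon with a double bond to nitrogen. Among the measured compounds shown here, no measured step carries hydroxyl groups on this ring; the nearest precedents are the two steps that exchanged a dimethoxyphenyl for 3-bromophenyl, both of which lowered the number. Read in reverse, they suggest that returning to an oxygen-bearing phenyl raises the number by a modest amount, so compound 4 is expected to show a step of a 2.1-fold higher number from compound 3 to compound 4 (0.31 log units; beyond the scatter) in this assay. The estimate for compound 4 is therefore 2000 nM, with a range from 900 nM to 4500 nM.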

Compound 4, half-maximal inhibitory concentration: 12700 nM
Compound 4: the middle estimate sits 6.4-fold (0.80 log units) below what was measured, outside the stated range (above it).
By their numbers in this assay, from the lowest: compounds 3, 1 and 2 (each within the scatter of the next, the first and the last beyond it); then compound 4.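

In this assay, the 2,4-dihydroxyphenyl group gives the largest step yet seen on the carbon with a double bond to nitrogen, a 13-fold higher number from compound 3 to compound 4 (1.12 log units; beyond the scatter), showing that this position can carry a far larger change than the earlier aryl exchanges revealed. The oxygen-bearing rings are also not interchangeable: there is a 6.5-fold higher number from compound 1 to compound 4 (0.81 log units; beyond the scatter), and the exchange of 2,4-dimethoxyphenyl for 2,4-dihydroxyphenyl alone gives a 4.5-fold higher number from compound 2 to compound 4 (0.65 log units; beyond the scatter), so methoxy and hydroxyl groups part clearly here. No available evidence bears on the origin of this rise.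

From the compounds shown here alone, whether the rise needs both hydroxyl groups or only one remains open. Also open, going by these compounds, is how a phenyl carrying an amine or a carboxylic acid would compare with the 2,4-dihydroxyphenyl and 3-bromophenyl groups.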